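A few compounds are considered here, and "the series" means these few. Any claim that something is new, unique, unknown or untested is made for them only; others in the source may bear on it.

Measured in an assay on HL-60 cells for agonist activity at vitamin D3 receptor (Homo sapiens), read by microscopy, with a stated time of 96 h; a higher number here means that more compound is needed for the effect, a lower number that less compound is needed:

compound 1, `CCN(CC)CCNC(=O)c1ccc(C(CC)(CC)c2ccc(OCC(O)C(C)(C)C)c(C)c2)n1CC`: 110 nM
compound 2, `CCn1c(C(=O)NCC(OC)OC)ccc1C(CC)(CC)c1ccc(OCC(O)C(C)(C)C)c(C)c1`: 150 nM
compound 3, `CC[C@@H](C)[C@H](NC(=O)c1ccc(C(CC)(CC)c2ccc(OCC(O)C(C)(C)C)c(C)c2)n1CC)C(=O)O`: 2.3 nM

Compound 3 gives the lowest number of the three, and the steps of a 48-fold lower number from compound 1 to compound 3 (1.68 log units; beyond the scatter) and a 65-fold lower number from compound 2 to compound 3 (1.81 log units; beyond the scatter) are both large and beyond the scatter. Compound 4, `CCn1c(C(=O)OCc2ccc(F)cc2)ccc1C(CC)(CC)c1ccc(OCC(O)C(C)(C)C)c(C)c1`, differs from compound 3 by (4-fluorobenzyl)oxy in place of (1-carboxy-2-methylbutyl)amino on a carbonyl carbon. Those two measured steps bear on this change in reverse: each shows that bringing in the 1-carboxy-2-methylbutyl group lowered the number greatly, and compound 4 gives that group up. Going by the values given here, no measured step covers the exchange of an amide for an ester itself. A large step to a higher number is therefore expected, a 65-fold higher number from compound 3 to compound 4 (1.81 log units; beyond the scatter). Compound 4 is estimated at 150 nM, between 40 nM and 600 nM.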

Compound 4, half-maximal effective concentration: > 50000 nM
Compound 4: only a limit was reported; the forecaster's own chance of this, stated with the estimate: 5%; middle value at least 330-fold (2.52 log units) away from the limit.
By their numbers in this assay, from the lowest: compound 3; then compounds 1 and 2 (each within the scatter of the next). At a limit, above all of these: compound 4.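

Compound 4 gives no exact number, only a limit: the limit of > 50000 nM in this assay, at which 1 of the 4 values shown sits. Putting (4-fluorobenzyl)oxy on this carbonyl carbon gives an at least 21000-fold higher number from compound 3 to compound 4 (4.33 log units; beyond the scatter), an at least 330-fold higher number from compound 2 to compound 4 (2.52 log units; beyond the scatter) and an at least 450-fold higher number from compound 1 to compound 4 (2.65 log units; beyond the scatter). The earlier compounds shown here varied only the group on an amide nitrogen, whereas this ester shows that a change at this position can cost far more than any step among those amides.

The change swaps the nitrogen link for oxygen and the chain for a 4-fluorobenzyl group at once, so the two effects cannot be separated. A (4-fluorobenzyl)amino group on the same carbonyl would tell them apart.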